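This account rests on a few compounds, and the source may have more. Where it says the series, first, only, none or still open, it means among the compounds named here.

Measured so far in a functional assay on SW-620 cells (Homo sapiens); a higher number here means a weaker inhibitor of growth, a lower number a stronger inhibitor of growth:
compound 1, `O=S(=O)(/C=C/c1ccc(Cl)cc1)Cc1ccc(Nc2ncnc3ccccc23)cc1`: 77000 nM
compound 2, `O=S(=O)(/C=C/c1ccc(F)cc1Cl)Cc1ccc(Nc2ncnc3ccccc23)cc1`: 100000 nM

Compound 2 stands highest of the two numbers in this assay; its nearest neighbour is compound 1, and the step of a 1.3-fold higher number from compound 1 to compound 2 (0.11 log units; within the scatter) lies within the scatter. Compound 3, `O=S(=O)(/C=C/c1ccc(F)cc1Cl)Cc1ccc(Nc2ncnc3cc(Cl)ccc23)cc1`, differs from compound 2 by chloro in place of hydrogen on an aromatic carbon, on the fused ring of the shared core. Among the measured compounds shown here, no measured step touches that ring; the one step known, a 1.3-fold higher number from compound 1 to compound 2 (0.11 log units; within the scatter), concerns the other end of the molecule and is itself within the scatter. The step of a 1.2-fold lower number from compound 2 to compound 3 (0.07 log units; within the scatter) is therefore expected to stay within the scatter, in no particular direction. Compound 3 is estimated at 85000 nM, with a range from 30000 nM to 250000 nM.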

Compound 3, concentration for 50% growth inhibition: > 100000 nM
Compound 3: only a limit was reported; the forecaster's own chance of this, stated with the estimate: 25%; at least 1.1-fold (0.07 log units) between middle value and limit.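

In this assay compound 3 gives > 100000 nM, a limit of the assay and not a number. For chloro in place of hydrogen on this aromatic carbon, the step is a number no lower from compound 2 to compound 3 (the limit leaves the size open) and its size cannot be read. The reading stops at the limit: the limit of > 100000 nM in this assay, at which 1 of the 3 values shown sits.

Still open, as far as these compounds go, is whether an amine or a methoxy group on this aromatic carbon would give a readable value in this assay. Also open, from the compounds shown here alone, is whether any change at this position gives a lower number.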